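This account rests on a few compounds, and the source may have more. Where it says the series, first, only, none or still open, it means among the compounds named here.

Measured so far:
compound 1 `CN(C)C(=O)/C=C1\CCc2c(F)cc(F)cc21`: 50 mg/kg
compound 2 `CC(C)NC(=O)/C=C1\CCc2ccc(F)cc21`: 96 mg/kg

Both numbers come from a functional assay on the whole organism with Mus musculus as the target; on this read-out lower numbers stand for an effect already at smaller amounts and higher numbers for an effect only at larger amounts of compound. With only these two values available, compound 2 at 96 mg/kg lies within the usual scatter of compound 1 at 50 mg/kg, so the two cannot be told apart.

The next compound is compound 3 `CC(C)NC(=O)/C=C1\CCc2c(F)cc(F)cc21`, which is compound 2 with fluoro in place of hydrogen on an aromatic carbon. Among the measured compounds shown here, no pair of measured compounds differs in one place only, so no measured step speaks directly to this change. The expectation is therefore a small move towards a lower number, and none beyond the scatter. The estimated step is a 1.4-fold lower number from compound 2 to compound 3 (0.14 log units; within the scatter). For compound 3 the expected value is 70 mg/kg, with an estimated range of 35 mg/kg to 150 mg/kg.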

Compound 3, dose for half-maximal effect: 50 mg/kg
Estimate against measurement, compound 3: 1.4-fold (0.15 log units) above, and the stated range covers the measured number.
By their numbers in this assay, from the lowest: compounds 1, 3 and 2 (each within the scatter of the next).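

In this assay, fluoro in place of hydrogen on an aromatic carbon, ortho to a fused ring and meta to a fluoro group, gives a 1.9-fold lower number from compound 2 to compound 3 (0.28 log units; within the scatter) and thus gives the series its first reading at this position: the added fluoro yields no difference that can be told from the scatter. Isopropylamino in place of dimethylamino on a carbonyl carbon gives no change at the digits printed from compound 1 to compound 3 (within the scatter) and shows that, with both ring fluoro groups present, these two amide groups cannot be told apart either. No supporting data bear on either step.

Going by these compounds, whether chloro or methoxy at this aromatic carbon would move the number beyond the scatter remains open. The same question stands for a morpholine amide or a longer chain on the amide nitrogen.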